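Cyclohexyl for a tert-butyl ester on the ring nitrogen

A few compounds are considered here, and "the series" means these few. Any claim that something is new, unique, unknown or untested is made for them only; others in the source may bear on it.

Within the data shown here, compound 3 `CC(C)(C)OC(=O)CCC[N+]1(C)CCc2c(sc(NC(=O)Nc3ccc(Cl)cc3)c2C(N)=O)C1` holds the lowest of the two numbers so far in a functional assay (strain AB) with Danio rerio as the target, read by microscopy, with a stated time of 1 h (on this read-out higher numbers stand for an effect only at larger amounts of compound and lower numbers for an effect already at smaller amounts), giving 250 nM. Its nearest neighbour, compound 2 `CCN1CCc2c(sc(NC(=O)Nc3ccc(Br)cc3)c2C(N)=O)C1`, gives 3130 nM in this assay. For compound 1 `CCN1CCc2c(sc(NC(=O)[C@@H]3CCCN3)c2C(N)=O)C1`, this assay reports only a limit, > 25000 nM. Among the measured compounds shown here, the one measured step, an at least 7.9-fold lower number from compound 1 to compound 2 (0.90 log units; beyond the scatter), concerns the carbonyl substituent and not the ring nitrogen. Compound 4 `C[N+]1(CC2CCCCC2)CCc2c(sc(NC(=O)Nc3ccc(Cl)cc3)c2C(N)=O)C1` differs from compound 3 at that nitrogen: cyclohexyl in place of 2-(tert-butoxycarbonyl)ethyl on a saturated chain carbon bound to an amine nitrogen in a ring. For the measured compounds named here, no measured step touches this position, so nothing here argues for a shift beyond the scatter; the change is expected to be a 1.2-fold higher number from compound 3 to compound 4 (0.08 log units; within the scatter). Compound 4 is therefore estimated at 300 nM in this assay, with a range from 100 nM to 900 nM.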

Compound 4, half-maximal effective concentration: 100 nM
Beside the measured number, compound 4's estimate is 3.0-fold (0.48 log units) above it; the measured number falls inside the stated range.
By their numbers in this assay, from the lowest: compound 4; then compound 3; then compound 2. At a limit, above all of these: compound 1.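

In this assay the ring nitrogen emerges as a place where the read-out moves, which the earlier step at the carbonyl substituent could not show: cyclohexyl in place of 2-(tert-butoxycarbonyl)ethyl gives a 2.5-fold lower number from compound 3 to compound 4 (0.40 log units; beyond the scatter) here. The effect therefore does not depend on the ester, since compound 4 lacks it. Nothing measured here bears on the reason for this step.

Going by these compounds, how a free carboxylic acid at the chain end would compare stays open. So does how a phenyl ring or a longer alkyl chain in place of cyclohexyl would read.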